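Chloro to Methoxycarbonyl: Expected Effect on Cell Growth

A few compounds are considered here, and "the series" means these few. Any claim that something is new, unique, unknown or untested is made for them only; others in the source may bear on it.

Compound 1, `Nc1ccccc1NC(=O)c1ccc(CSC(=S)N2CCc3ccccc32)cc1`, gives 44% in a functional assay on MGC-803 cells (Homo sapiens) for antiproliferative activity, read by CCK-8 assay, with a stated time of 72 h, tested at 2 uM; on this read-out lower numbers stand for a weaker effect and higher numbers for a stronger effect at the one concentration tested.
Compound 2, `Nc1ccccc1NC(=O)c1ccc(CSC(=S)N2CCc3cc(Cl)ccc32)cc1`, gives 57.7%.
Compound 3, `CN(Cc1ccncc1)C(=S)SCc1ccc(C(=O)Nc2ccccc2N)cc1`, gives 38.1%.

Compound 2 stands highest of these three numbers; its gap to compound 1 and its larger gap to compound 3 are both beyond the scatter. Compound 4, `COC(=O)c1ccc2c(c1)CCN2C(=S)SCc1ccc(C(=O)Nc2ccccc2N)cc1`, differs from compound 2 in one place: methoxycarbonyl in place of chloro on an aromatic carbon. Among the compounds with values here, the only measured step at that position is a number 13.7 percentage points higher from compound 1 to compound 2 (beyond the scatter), where chloro entered in place of hydrogen. Within the data shown here, no measured compound carries methoxycarbonyl, so the size of its effect is not known. The estimate therefore falls back toward compound 1, as a modest downward step a number 9.7 percentage points lower from compound 2 to compound 4 (within the scatter). Compound 4 is expected to give 48%, with a range from 30% to 65%.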

Compound 4, a percentage reported as inhibition, at one concentration (the size of the read-out at that concentration, not a potency): 37.8%
The estimate for compound 4 lay 10.2 percentage points above the measured number, and the stated range covers the measured number.
By their numbers in this assay, from the lowest: compounds 4, 3 and 1 (each within the scatter of the next); then compound 2.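

Putting methoxycarbonyl in place of chloro on this aromatic carbon gives a number 19.9 percentage points lower from compound 2 to compound 4 (beyond the scatter) in this assay and so shows that the gain seen with chloro does not carry over to every group placed here. Methoxycarbonyl in place of hydrogen gives a number 6.2 percentage points lower from compound 1 to compound 4 (within the scatter) and so adds nothing that can be told apart from the unsubstituted ring. No measurement shown here explains the difference between the two groups. Going by these compounds, whether the gain is special to chloro remains open. Bromo, methyl, an amine or a carboxylic acid on this carbon would help to settle that.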